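Phenylpiperazine oximes: cyano added on the phenyl ring

The source may report more compounds than this note shows. Statements on the series, on what has been measured and on what is new or still open speak of the compounds shown alone.

Working notes on a small set of oxime-bearing piperazines. Compound 1 `O/N=C(\CCN1CCN(c2ccccn2)CC1)c1ccccc1` carries a pyridyl on the piperazine and an unsubstituted oxime; in a functional assay on HEK293 cells with D(4) dopamine receptor (Homo sapiens) as the target, read by FLIPR (on this read-out lower numbers stand for smaller maximal responses and higher numbers for larger maximal responses), compound 1 gives 70%. Compound 2 `O/N=C(\CCN1CCN(c2ccccn2)CC1)c1cc(F)cc(F)c1` has 3,5-difluorophenyl in place of phenyl on the carbon with a double bond to nitrogen, and compound 2 gives 74%; the step of a number 4 percentage points higher from compound 1 to compound 2 (within the scatter) stays inside the scatter. Compound 3 `CCO/N=C(\CCN1CCN(c2ccccc2)CC1)c1ccccc1` differs in two places from compound 1, with an ethyl on the oxime oxygen and phenyl in place of pyridyl on the piperazine; compound 3 gives 80%, a number that sits within the scatter of both compound 2 and compound 1, so the three measured compounds cannot be separated on this read-out.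

Compound 4 `CCO/N=C(\CCN1CCN(c2ccccc2C#N)CC1)c1ccccc1` is the next step from compound 3: cyano in place of hydrogen on an aromatic carbon. Within the data shown here, no measured step touches this part of the molecule, and the one measured step, from compound 1 to compound 2, was itself within the scatter. Nothing here supports a change beyond the scatter in either direction, so the step of a number 2 percentage points lower from compound 3 to compound 4 (within the scatter) is expected to stay small. Compound 4 is therefore estimated at 78% in this assay, with a range from 62% to 92%.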

Compound 4, largest response reached (reported as efficacy), in percent of the reference or control that the assay uses: 82%
Beside the measured number, compound 4's estimate is 4 percentage points below it; the range from low to high includes it.
By their numbers in this assay, from the lowest: compounds 1, 2, 3 and 4 (each within the scatter of the next, the first and the last beyond it).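

Phenyl to 2-cyanophenyl is the first measured change at this position, on an aromatic carbon of a six-membered aromatic ring of carbon only, ortho to a large group, and in this assay it reads as a number 2 percentage points higher from compound 3 to compound 4 (within the scatter). Among these compounds, for this one pair, the earlier compounds gave no reading at this position, and a cyano of 2 heavy atoms with 1 hydrogen-bond acceptor now leaves a maximal response that cannot be told apart from that of compound 3 on this read-out. No available data bear on the reason for this result.

What the compounds shown leave open is how this position answers to other groups, such as an amine, a carboxylic acid or a methoxy group, and whether the cyano reads the same on other aromatic carbons of this ring. Also open, on these data alone, is whether cyano in place of hydrogen gives a comparable step with a longer chain in place of the ethyl on the oxime oxygen, or with the unsubstituted oxime of compound 1.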